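Methyl for hydrogen on the aryl ether ring of compound 1

A few compounds are considered here, and "the series" means these few. Any claim that something is new, unique, unknown or untested is made for them only; others in the source may bear on it.

Measured so far in an assay for inhibition of Myeloperoxidase (Homo sapiens), read by Amplex Red, with stated times of 10 min and 15 min; on this read-out lower numbers stand for stronger inhibition and higher numbers for weaker inhibition:
compound 1 `Nc1cc(OCc2cccc(-c3cccc(F)c3)c2)c2nn[nH]c2n1`: 21 nM
compound 2 `Nc1cc(OCc2cc(-c3cccc(F)c3)ccc2Cl)c2nn[nH]c2n1`: 24 nM

Compound 1 and compound 2 give numbers that lie within the scatter of each other; on this assay neither stands apart. For the measured compounds named here, the one measured step, a 1.1-fold higher number from compound 1 to compound 2 (0.06 log units; within the scatter), is the only comparison so far, and it shows that a small substituent placed on an aromatic carbon of this core left the number unchanged beyond the scatter.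

Compound 3 `Cc1c(COc2cc(N)nc3[nH]nnc23)cccc1-c1cccc(F)c1` differs from compound 1 by methyl in place of hydrogen on an aromatic carbon. Going by the values given here, no measured pair shows exactly this exchange; the closest guide is the step from compound 1 to compound 2, which is also a single small group entering on an aromatic carbon and which stayed within the scatter. On that basis no step beyond the scatter is expected for compound 3, and the step from compound 1 to compound 3 is expected to be a 1.2-fold higher number from compound 1 to compound 3 (0.08 log units; within the scatter). Compound 3 is therefore estimated at 25 nM, with a range of 10 nM to 60 nM.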

Compound 3, half-maximal inhibitory concentration: 23 nM
Beside the measured number, compound 3's estimate is 1.1-fold (0.04 log units) above it; low and high end bracket the measured number.
By their numbers in this assay, from the lowest: compounds 1, 3 and 2 (each within the scatter of the next).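

In this assay the exchange of hydrogen for methyl on the aromatic carbon ortho to a 3-fluorophenyl group gives a 1.1-fold higher number from compound 1 to compound 3 (0.04 log units; within the scatter) and so stays within the scatter. This adds a direct reading at this carbon: one added carbon, ortho to a large group, is tolerated here without a step beyond the scatter, which the chloro exchange in compound 2 could not show for this position. No supporting data are available to explain this result.

A single small group at this carbon says nothing about how far the tolerance extends, so an amine, a carboxylic acid or a longer chain such as propyl remains an open test. On these data alone, whether any group here can move the number beyond the scatter, in either direction, also remains open.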